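The source may report more compounds than this note shows. Statements on the series, on what has been measured and on what is new or still open speak of the compounds shown alone.

Measured compounds:
compound 1 `CCOC(=O)c1cc(/C=C/c2ccccc2)on1`: "not determined" (no result reported)
compound 2 `CCOC(=O)c1cc(/C=C/c2cccc(C(F)(F)F)c2)on1`: > 128000 nM
compound 3 `CCOC(=O)c1cc(/C=C/c2ccc(C(F)(F)F)cc2)on1`: "not determined" (no result reported)

In an ADME assay on Vero cells (Chlorocebus sabaeus) for cytotoxicity, with a stated time of 72 h (on this read-out lower numbers stand for stronger inhibition and higher numbers for weaker inhibition), compound 1 has no result, so there is no number to place it against. Compound 2 gives > 128000 nM in this assay, which is a limit of the assay and not a number. Compound 3, like compound 1, has no result in this assay. Of the three values shown, one therefore sits at the limit of > 128000 nM in this assay, at which 1 of the 3 values shown sits, and the other two are missing. Compound 4 `CCOC(=O)c1cc(/C=C/c2ccccc2CC)on1` differs from compound 1 by ethyl in place of hydrogen on an aromatic carbon. Within the data shown here, with no measured step between any two compounds, no size or direction of change can be read from the data, and no shift beyond the usual scatter is expected in this assay. Compound 4 is expected to give about 128000 nM, within 30000 nM to 400000 nM.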

Compound 4, half-maximal inhibitory concentration: > 128000 nM
Compound 4: a limit, no number; the forecaster's own chance of this, stated with the estimate: 75%; the middle value sits exactly at the limit.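

No step can be read from compound 1 to compound 4 in this assay: compound 1 has no number, and compound 4 gives only a limit. The compounds shown leave open whether ethyl in place of hydrogen changes this read-out at all.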